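Swapping the aryl ether on a shared diamino core

The source may report more compounds than this note shows. Statements on the series, on what has been measured and on what is new or still open speak of the compounds shown alone.

Three compounds built on the same core were examined in a functional assay on Malme-3M cells (Homo sapiens) for inhibition, read by sulforhodamine B assay, with a stated time of 48 h; on this read-out higher numbers stand for weaker inhibition of growth and lower numbers for stronger inhibition of growth. Compound 1, `Nc1cc(N)c2nc(-c3ccccc3)c(Oc3ccc(Cl)c(Cl)c3)nc2c1`, gives 15800 nM in this assay. Compound 2, `CCOC(=O)[C@H](CCC(=O)O)NC(=O)c1ccc(Oc2nc3cc(N)cc(N)c3nc2-c2ccccc2)cc1`, gives 18600 nM in this assay, and compound 3, `CCOC(=O)[C@H](CCC(=O)O)NC(=O)c1ccc(CNc2nc3cc(N)cc(N)c3nc2-c2ccccc2)cc1`, gives 20400 nM in this assay. Compound 1 shows the lowest of the three numbers, yet its gaps to compound 2 and to compound 3 both lie within the scatter of repeated measurements, so the three compounds cannot be set apart from one another in this assay.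

Compound 4, `COc1ccc(Sc2nc3cc(N)cc(N)c3nc2-c2ccccc2)cc1`, has not yet been measured. It differs from compound 1 in one place: (4-methoxyphenyl)sulfanyl in place of 3,4-dichlorophenoxy on an aromatic carbon. The replacing group sits on an aromatic carbon of a six-membered aromatic ring with two nitrogen, part of a fused system of two rings, with the phenyl group ortho to it.

For the measured compounds named here, no step between two measured compounds is available here, and the three numbers at hand show no spread beyond the scatter. The account therefore expects that a 1.1-fold higher number from compound 1 to compound 4 (0.03 log units; within the scatter) will be a step of no size beyond the scatter in this assay, in either direction. For compound 4 the expected value in this assay is 17000 nM, within a range from 7000 nM to 40000 nM.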

Compound 4, concentration for 50% growth inhibition: 33100 nM
Compound 4: the middle estimate sits 1.9-fold (0.29 log units) below what was measured; low and high end bracket the measured number.
By their numbers in this assay, from the lowest: compounds 1, 2, 3 and 4 (each within the scatter of the next, the first and the last beyond it).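

For the compounds shown here, the step in this assay is the first in this set to clear the scatter: (4-methoxyphenyl)sulfanyl in place of 3,4-dichlorophenoxy, on the aromatic carbon next to the ring nitrogen and ortho to a phenyl group, gives a 2.1-fold higher number from compound 1 to compound 4 (0.32 log units; beyond the scatter), a modest step towards weaker inhibition of growth. It shows that this position is not wholly indifferent to what it carries, even when the leaving and entering groups match in heavy-atom count and each holds one six-membered aromatic ring of carbon only, although the step is small and rests on a single pair. No measurement at hand accounts for the step, which bundles together the swap of the linking oxygen for sulfur and the swap of the two chlorines for a methoxy group.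

The compounds shown leave open which of those two swaps carries the step, a question that 4-methoxyphenoxy or (3,4-dichlorophenyl)sulfanyl at the same carbon would separate. They also leave open how a plain phenylamino group or an unsubstituted phenoxy group would read at this position on the shared core.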